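A few compounds are considered here, and "the series" means these few. Any claim that something is new, unique, unknown or untested is made for them only; others in the source may bear on it.

Of the compounds shown here, two have so far been measured in a functional assay on MCF7 cells (Homo sapiens) for cytotoxicity, read by MTT assay and propidium iodide staining, with a stated time of 24 h; a higher number here means a weaker inhibitor, a lower number a stronger inhibitor. Compound 1 `CCOc1ccccc1-c1nnc(SCC(=O)c2ccc(Br)cc2)o1` gives 460 nM, and compound 2 `O=C(CSc1nnc(-c2ccnc(Cl)c2)o1)c1ccc(Br)cc1` gives 270 nM. The two numbers lie within the scatter of each other, so compound 2 stands level with compound 1. Compound 3 `COc1ccccc1-c1nnc(SCC(=O)c2ccc(Br)cc2)o1` has not yet been measured. It differs from compound 2 on an aromatic carbon of a five-membered aromatic ring with 2 nitrogen and 1 oxygen, where 2-methoxyphenyl appears in place of 2-chloropyridin-4-yl: 2-methoxyphenyl in place of 2-chloropyridin-4-yl on an aromatic carbon. Going by the values given here, no measured step is available to gauge this exchange, so the expectation rests on the two values alone. Compound 3 is expected to fall near compound 1 at 460 nM. This implies an expected 1.5-fold higher number from compound 2 to compound 3 (0.17 log units; within the scatter), towards a somewhat higher number but not beyond the scatter. For compound 3 the estimated value is 400 nM, with an expected range from 150 nM to 1000 nM.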

Compound 3, half-maximal inhibitory concentration: 600 nM
Compound 3: the middle estimate sits 1.5-fold (0.18 log units) below what was measured, and the stated range covers the measured number.
By their numbers in this assay, from the lowest: compounds 2, 1 and 3 (each within the scatter of the next, the first and the last beyond it).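

In this assay, the position on the aromatic carbon of the five-membered ring now has its first measured step: 2-methoxyphenyl in place of 2-chloropyridin-4-yl gives a 2.2-fold higher number from compound 2 to compound 3 (0.35 log units; beyond the scatter), so this exchange separates the two compounds, though only modestly. Within the aryl series, hydrogen in place of methyl on the chain carbon bound to the oxygen gives a 1.3-fold higher number from compound 1 to compound 3 (0.12 log units; within the scatter), so this smaller change produces no separation beyond the scatter. Nothing available bears on the reason for either step.

Because the ring, its chlorine and its methoxy group all differ in one exchange, the step cannot be assigned to any one of them, and a 2-chlorophenyl or an unsubstituted pyridin-4-yl group would be needed to divide it. From the compounds shown here alone, how an amine or a carboxylic acid at this position would read also remains open.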